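The compounds below may be only part of what the source reports. "The series", "measured", "known", "first", "only" and "open" are said of these compounds alone.

Compound 2, `CCCCCCCCCCCCCCCCCCNC(=O)[C@H]1CSC(c2c(Cl)cccc2Cl)N1`, reaches in a functional assay on RH7777 cells (Homo sapiens) for antiproliferative activity against RH7777 (Rattus norvegicus), read by sulforhodamine B assay (a higher number here means a weaker inhibitor, a lower number a stronger inhibitor), only the limit > 20000 nM, so no number is known for it. Compound 1, `CCCCCCCCCCCCCCCCCCNC(=O)[C@H]1CSC(c2cc(F)cc(F)c2)N1`, likewise stops at the limit > 20000 nM. The step that the two limits leave unreadable from compound 1 to compound 2 therefore gives no readable size, and the limit of > 20000 nM in this assay, at which 2 of the 2 values shown sit, is all that the measured pair shows. Compound 3, `CCCCCCCCCCCCCCCCCCNC(=O)[C@H]1CSC(c2ccc(F)c(Br)c2)N1`, arises through (3-bromo-4-fluorophenyl in place of 2,6-dichlorophenyl on a saturated ring carbon). Within the data shown here, no measured step gives a readable size for this kind of change, so the expectation rests on both measured compounds sitting at the limit. Compound 3 is expected near 25000 nM, with a range from 8000 nM to 60000 nM. The expected step is a step that the limit leaves unreadable from compound 2 to compound 3, no change that could be read.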

Compound 3, half-maximal inhibitory concentration: 20000 nM
Estimate against measurement, compound 3: 1.3-fold (0.10 log units) above; measured number inside the range.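

In this assay, among these compounds, compound 3 gives 20000 nM, the first real number at this position on the saturated ring carbon, so a 3-bromo-4-fluorophenyl group here yields a value that can be read, with a number no higher from compound 2 to compound 3 (the limit leaves the size open) and a number no higher from compound 1 to compound 3 (the limit leaves the size open). Both steps still cannot be read, so no size can be given for this change. Compound 1 and compound 2 remain limits, not numbers: the limit of > 20000 nM in this assay, at which 2 of the 3 values shown sit.

Still open, going by these compounds, is whether a phenyl ring carrying a methoxy or a hydroxyl group at this carbon would give a clearly lower number.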